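A Trifluorophenyl Swap at the Edge of Detection

The source may hold more compounds than are shown below. What is called first, only, known or untested is meant among the compounds shown, and "the series" means these compounds.

Compound 2 `COc1ccc(CNc2ncnc3c2ncn3[C@@H]2O[C@H](CO)[C@@H](O)[C@H]2O)c(OC)c1` was tested in a functional assay on K562 cells (Homo sapiens) for antiproliferative activity, with a stated time of 72 h; a higher number here means a weaker inhibitor, a lower number a stronger inhibitor. Compound 2 gives only a limit there, > 166000 nM. Its closest measured relative is compound 1 `COc1cccc(CNc2ncnc3c2ncn3[C@@H]2O[C@H](CO)[C@@H](O)[C@H]2O)c1`, which differs from it in a single group on the saturated chain carbon bound to a nitrogen on the aromatic ring. Compound 1 likewise gives only a limit, > 166000 nM. The step that the two limits leave unreadable from compound 1 to compound 2 therefore has no readable size, and the one firm observation is the limit of > 166000 nM in this assay, at which 2 of the 2 values shown sit, which places both measured compounds at the same edge of the assay. Compound 3 `OC[C@H]1O[C@@H](n2cnc3c(NCc4c(F)ccc(F)c4F)ncnc32)[C@H](O)[C@@H]1O` is the next change along this series: 2,3,6-trifluorophenyl in place of 2,4-dimethoxyphenyl on a saturated chain carbon bound to a nitrogen on an aromatic ring. Among the compounds with values here, no measured step shows what such a group does in this position, and the single measured step offers no size to lean on. The expectation is that compound 3 will again sit at the limit, so the step that the limit leaves unreadable from compound 2 to compound 3 is estimated as essentially flat. The estimate for compound 3 is 200000 nM, within 60000 nM to 600000 nM, with a strong chance that only a limit is reported once more.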

Compound 3, half-maximal inhibitory concentration: > 166000 nM
Compound 3 gave a limit, no number (the forecaster's own chance of this, stated with the estimate: 80%); the middle value does not contradict the limit.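

Compound 3 also gives only a limit in this assay, so the steps among compound 1, compound 2 and compound 3 cannot be read: the limit of > 166000 nM in this assay, at which 3 of the 3 values shown sit. The compounds shown leave open how strongly any of them acts on these cells, and whether any group at this place on the shared core would give a readable value.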